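The compounds below may be only part of what the source reports. "The series", "measured", "known", "first", "only" and "open" are said of these compounds alone.

Of the compounds shown here, two have so far been read in a physicochemical assay for solubility, read by HPLC, in phosphate buffer, with a stated time of 20 min, at pH 2.0; on this read-out higher numbers stand for higher solubility and lower numbers for lower solubility. Compound 1 `CCC(CC)O[C@@H]1C=C(C(=O)O)C[C@H](NC(C)=N)[C@H]1NC(C)=O` gives > 50000000 nM, which is a limit of the assay and not a number. Compound 2 `CCOC(=O)C1=C[C@@H](OC(CC)CC)[C@H](NC(C)=O)[C@@H](N/C(C)=N/O)C1` gives > 50000000 nM, which is likewise a limit and not a number. Compound 2 therefore has no exact position on this scale, and the whole record so far comes down to the limit of > 50000000 nM in this assay, at which 2 of the 2 values shown sit.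

The next compound to be read is compound 3 `CCOC(=O)C1=C[C@@H](OC(CC)CC)[C@H](NC(C)=O)[C@@H](N/C(N)=N\O)C1`, which keeps the core of compound 2 and differs from it at one place, on an amine nitrogen: a group of 4 heavy atoms (1 carbon, 2 nitrogen, 1 oxygen; no ring) in place of a group of 4 heavy atoms (2 carbon, 1 nitrogen, 1 oxygen; no ring), on an amine nitrogen. Among the compounds with values here, the exchanged groups match in heavy-atom count, but no measured step between compounds is available to size the change. Within the data shown here, no shift beyond the usual scatter is expected in this assay, and this expectation rests only on compound 2 at > 50000000 nM and on the one structural change. The expected size of the move is a number no higher from compound 2 to compound 3 (the limit leaves the size open). For compound 3 the estimated value is 50000000 nM, with an expected range from 20000000 nM to 100000000 nM.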

Compound 3, solubility: > 50000000 nM
Compound 3 ended at the assay's limit (the forecaster's own chance of this, stated with the estimate: 75%); the middle value sits exactly at the limit.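

Compound 2 gives > 50000000 nM in this assay, which is a limit of the assay and not a number. Compound 3 gives > 50000000 nM, likewise a limit, so no step can be read between compound 2 and compound 3. The compounds shown leave open whether the exchange on the amine nitrogen moves this read-out at all, and where any of them lies on the scale: the limit of > 50000000 nM in this assay, at which 3 of the 3 values shown sit.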